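This account rests on a few compounds, and the source may have more. Where it says the series, first, only, none or still open, it means among the compounds named here.

Working notes on the series.

Compound 1 `O=C(Nc1ccc(C(F)(F)F)cc1)c1csc(-c2c(Cl)cccc2Cl)n1` carries a 2,6-dichlorophenyl on an aromatic carbon of the shared core. In an assay on CHO cells, read by calcium flux (a higher number here means a weaker inhibitor, a lower number a stronger inhibitor), compound 1 gives only a limit, > 4000 nM, not a number. Compound 2 `O=C(Nc1ccc(C(F)(F)F)cc1)c1csc(Nc2ccccc2Cl)n1` puts a (2-chlorophenyl)amino in that place. In this assay, among the measured compounds shown here, compound 2 gives 1410 nM, the only number obtained so far; the other value is the limit of > 4000 nM in this assay, at which 1 of the 2 values shown sits. For the measured compounds named here, the step of an at least 2.8-fold lower number from compound 1 to compound 2 (0.45 log units; beyond the scatter) is the single measured step, and it is at least modest.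

Compound 3 `Cc1cccc(C)c1Nc1nc(C(=O)Nc2ccc(C(F)(F)F)cc2)cs1` differs from compound 2 by 2,6-dimethylphenyl in place of 2-chlorophenyl on a nitrogen on an aromatic ring. Going by the values given here, no measured step changes the substituents of the aryl on that nitrogen, so the step from compound 1 to compound 2 bears on it only loosely and gives no direction. In this assay compound 3 is therefore expected to stay close to compound 2, with an estimated step of a 1.1-fold higher number from compound 2 to compound 3 (0.03 log units; within the scatter), within the scatter. Compound 3 is estimated at 1500 nM, with a range of 500 nM to 4500 nM.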

Compound 3, half-maximal inhibitory concentration: 82 nM
For compound 3 the middle estimate is 18-fold (1.26 log units) above the measured one; measured number outside the range, below it.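

In this assay the change on the nitrogen, a 17-fold lower number from compound 2 to compound 3 (1.24 log units; beyond the scatter), is large, so the substituents of the aryl on that nitrogen weigh heavily in this series, which the earlier step could not show. The (2,6-dimethylphenyl)amino group also gives an at least 48-fold lower number from compound 1 to compound 3 (1.68 log units; beyond the scatter), a larger step than the one reached with the (2-chlorophenyl)amino group. Compound 1 gives only a limit, not a number: the limit of > 4000 nM in this assay, at which 1 of the 3 values shown sits.

The compounds shown leave open whether the step goes with the loss of the chlorine, the arrival of the methyl groups or the presence of two substituents on the aryl, a question that (2,6-dichlorophenyl)amino or (2-methylphenyl)amino on the shared core would address. Also open, as far as these compounds go, is how ethyl groups in place of the methyl groups would read.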